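Same Benzyl Swap, Now on the Acyl Urea Pair

The compounds below may be only part of what the source reports. "The series", "measured", "known", "first", "only" and "open" are said of these compounds alone.

Compound 1 `Cc1ccc(COc2ccc(C(=O)NC(=S)Nc3ccc(C)c(-c4nc5ccccc5[nH]4)c3)cc2)cc1` gives 4980 nM in a functional assay on MGC-803 cells (Homo sapiens) for inhibition, read by MTT assay, with a stated time of 48 h; on this read-out lower numbers stand for stronger inhibition and higher numbers for weaker inhibition. Compound 2 `Cc1ccc(NC(=S)NC(=O)c2ccc(OCc3cccc(F)c3)cc2)cc1-c1nc2ccccc2[nH]1` is reported only as a limit of this assay, at > 100000 nM. The step between them is an at least 20-fold higher number from compound 1 to compound 2 (1.30 log units; beyond the scatter), and the structural change behind it is 3-fluorophenyl in place of 4-methylphenyl on a saturated chain carbon bound to an oxygen on an aromatic ring. Because (the limit of > 100000 nM in this assay, at which 1 of the 3 values shown sits), the size of that step is known only as a lower bound.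

Compound 3 `Cc1ccc(COc2ccc(C(=O)NC(=O)Nc3ccc(C)c(-c4nc5ccccc5[nH]4)c3)cc2)cc1` gives 4250 nM in this assay; its value and that of compound 1 lie within the usual scatter of each other. The difference between the core of compound 3 and the core of compound 1 is not broken down here.

Compound 4 `Cc1ccc(NC(=O)NC(=O)c2ccc(OCc3cccc(F)c3)cc2)cc1-c1nc2ccccc2[nH]1` has not yet been measured in this assay. It differs from compound 3 by 3-fluorophenyl in place of 4-methylphenyl on a saturated chain carbon bound to an oxygen on an aromatic ring, the same change that turned compound 1 into compound 2, at the same place. Since that earlier step was large, a step of similar size, at least, is expected from compound 3 to compound 4, namely a 14-fold higher number from compound 3 to compound 4 (1.15 log units; beyond the scatter). Compound 4 is therefore expected to give about 60000 nM in this assay, estimated to fall between 15000 nM and 200000 nM, with a real chance that only a limit is reported.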

Compound 4, half-maximal inhibitory concentration: 44800 nM
Beside the measured number, compound 4's estimate is 1.3-fold (0.13 log units) above it, and the stated range covers the measured number.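

On the core of compound 3, putting 3-fluorophenyl in place of 4-methylphenyl on the saturated chain carbon bound to the oxygen in this assay gives an 11-fold higher number from compound 3 to compound 4 (1.02 log units; beyond the scatter), so the change weakens inhibition on both cores shown, and by a large step each time. Set side by side, the two steps read: the same change on two cores in this assay, an at least 20-fold higher number (1.30 log units; beyond the scatter) from compound 1 to compound 2 and an 11-fold higher number (1.02 log units; beyond the scatter) from compound 3 to compound 4; the limit leaves it open whether they differ. The pairs therefore show that the direction carries from one core to the other, but they do not show that the size carries too, as the first step has only a lower bound and compound 2 is reported only as a limit: the limit of > 100000 nM in this assay, at which 1 of the 4 values shown sits.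

The compounds shown leave open whether the weaker inhibition goes with the fluorine that enters or with the methyl that leaves, a question an unsubstituted benzyl group on the same oxygen could help to separate. They also leave open how a chlorobenzyl or a methoxybenzyl group would fare on either core.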